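This account rests on a few compounds, and the source may have more. Where it says the series, first, only, none or still open, it means among the compounds named here.

Working notes on the series.

Of the compounds shown here, three of the shared core have been measured in an assay on isolated protein for inhibition of ubiquitin carboxyl-terminal hydrolase 7 (Homo sapiens), read by fluorescence, with stated times of 30 min and 1 h; a lower number here means a stronger inhibitor, a higher number a weaker inhibitor. Compound 1 `O=C([C@H]1Cc2cc(Cl)cc(-c3ccnc4cc(CO)sc34)c2O1)N1CCNCC1` gives 43 nM. Compound 2 `O=C([C@H]1Cc2cc(Cl)cc(-c3ccnc4cc(C5(O)COC5)sc34)c2O1)N1CCNCC1` gives 73 nM, and a 1.7-fold higher number from compound 1 to compound 2 (0.23 log units; within the scatter). Compound 3 `O=C([C@H]1Cc2cc(Cl)cc(-c3ccnc4cc(Cn5cnccc5=O)sc34)c2O1)N1CCNCC1` gives 27 nM, the lowest of the three numbers; a 1.6-fold lower number from compound 1 to compound 3 (0.20 log units; within the scatter), while a 2.7-fold lower number from compound 2 to compound 3 (0.43 log units; beyond the scatter).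

Compound 4 `Cc1cc2nccc(-c3cc(Cl)cc4c3O[C@@H](C(=O)N3CCNCC3)C4)c2s1` is not yet measured. Compared with compound 3, the change is a hydrogen atom in place of a group of 7 heavy atoms (4 carbon, 2 nitrogen, 1 oxygen; one six-membered aromatic ring with 2 hetero atoms), on a saturated chain carbon bound to an aromatic carbon. Among the compounds with values here, the one measured step that bears on it is the step from compound 1 to compound 3, where this same group entered in place of one oxygen atom and the number moved only within the scatter. Taking it out again, now in favour of hydrogen, is therefore expected to give at most a small step; no step beyond the scatter is expected in this assay, and the expected step is a 1.9-fold higher number from compound 3 to compound 4 (0.27 log units; within the scatter). Compound 4 is expected to come in at about 50 nM, between 20 nM and 130 nM.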

Compound 4, half-maximal inhibitory concentration: 130 nM
For compound 4 the middle estimate is 2.6-fold (0.41 log units) below the measured one; low and high end bracket the measured number.
By their numbers in this assay, from the lowest: compounds 3, 1, 2 and 4 (each within the scatter of the next, the first and the last beyond it).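

With a hydrogen on the saturated chain carbon bound to an aromatic carbon, leaving a plain methyl, the number in this assay rises beyond the scatter on both readable comparisons: a 4.8-fold higher number from compound 3 to compound 4 (0.68 log units; beyond the scatter) and a 3.0-fold higher number from compound 1 to compound 4 (0.48 log units; beyond the scatter). Hydroxy and the group of 7 heavy atoms, which compound 1 and compound 3 could not separate, therefore both stand apart from hydrogen at this place, which the earlier compounds could not show. The pattern does not hold for every group on the aromatic carbon, since compound 2 goes against it, with a 1.8-fold higher number from compound 2 to compound 4 (0.25 log units; within the scatter), and no measurement at hand accounts for these steps.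

Open, as far as these compounds go, is whether a methoxy group or an amine on the same chain carbon would stay with compound 1 and compound 3 or with compound 4. From the compounds shown here alone, a longer chain ending in hydroxy, or a carboxylic acid, is equally open.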